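A few compounds are considered here, and "the series" means these few. Any claim that something is new, unique, unknown or untested is made for them only; others in the source may bear on it.

The measured compounds:
compound 1, `Cc1ccc(C2=NN(C(=O)CN3CCCCC3)C(c3ccccc3O)C2)cc1`, in an assay on isolated protein for inhibition of Amine oxidase [flavin-containing] A (Homo sapiens), read by fluorescence, with stated times of 15 min and 20 min (a higher number here means a weaker inhibitor, a lower number a stronger inhibitor), gives 11300 nM
compound 2, `CC1=NN(C(=O)CN2CCCCC2)C(c2cc(Br)cc(Br)c2O)C1`, in this assay gives 7800 nM

Compound 2 carries the lower of the two numbers, yet compound 1 lies within the scatter of it, so neither can be called the stronger inhibitor on what has been measured. Compound 3, `CC1=NN(C(=O)CN2CCNCC2)C(c2cc(Br)cc(Br)c2O)C1`, has not yet been measured in this assay. It differs from compound 2 in a single place: piperazin-1-yl in place of piperidin-1-yl on a saturated chain carbon bound to a carbonyl carbon. Going by the values given here, no pair of measured compounds shows this same change, so there is no measured precedent for its size. The ring stays six-membered and non-aromatic and sits at the same place on the chain; one ring nitrogen and one hydrogen-bond donor come in. With nothing in the data that speaks for a large effect, the step expected in this assay is small, inside the usual scatter, and its direction is open. The estimate for compound 3 is 9000 nM, with a range from 3000 nM to 30000 nM. That estimate means an expected step of a 1.2-fold higher number from compound 2 to compound 3 (0.06 log units; within the scatter). Among the compounds with values here, it rests on compound 2 alone because 7800 nM is the only value with the same core.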

Compound 3, half-maximal inhibitory concentration: 2000 nM
For compound 3 the middle estimate is 4.5-fold (0.65 log units) above the measured one; the whole stated range lies above it.
By their numbers in this assay, from the lowest: compound 3; then compounds 2 and 1 (each within the scatter of the next).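

In this assay, going by these compounds alone, the change to piperazin-1-yl in place of piperidin-1-yl on a saturated chain carbon bound to a carbonyl carbon gives a 3.9-fold lower number from compound 2 to compound 3 (0.59 log units; beyond the scatter) and is the first step beyond the scatter in this small set. It shows that the number at this position responds to the make-up of the six-membered non-aromatic ring, even with the ring size and its place on the chain unchanged and with only a second ring nitrogen and a hydrogen-bond donor coming in. Nothing at hand bears on why the number falls, so the step stands as an observation only.

The compounds shown do not tell whether the ring nitrogen or its hydrogen carries the step, a question that morpholin-4-yl or 4-methylpiperazin-1-yl at the same place could address. They also leave open whether the same change would give a step of similar size on the core of compound 1, or whether an open-chain amine such as dimethylamino could stand in for the ring.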